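A few compounds are considered here, and "the series" means these few. Any claim that something is new, unique, unknown or untested is made for them only; others in the source may bear on it.

Compound 3 `CCn1c(/C=C2/C(=O)Nc3ccc(Br)cc32)nc2ccccc21` gives 42700 nM in a functional assay on PC-3 cells (Homo sapiens) for cytotoxicity, read by MTT assay, with a stated time of 48 h (on this read-out higher numbers stand for weaker inhibition and lower numbers for stronger inhibition), the higher of the two numbers recorded in it. The nearest is compound 1 `CC(C)n1c(/C=C2/C(=O)Nc3ccc(Br)cc32)nc2ccccc21`, which gives 10700 nM in this assay. Compound 2 `Cn1c(/C=C2/C(=O)Nc3ccc([N+](=O)[O-])cc32)nc2ccccc21` is recorded in this assay only as a limit, > 50000 nM, and not as a number. Compound 4 `Cn1c(/C=C2/C(=O)Nc3ccc(Br)cc32)nc2ccccc21` has not yet been measured in this assay. It differs from compound 3 by hydrogen in place of methyl on a saturated chain carbon bound to an aromatic nitrogen.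

For the measured compounds named here, one measured step bears directly on this change: a 4.0-fold higher number from compound 1 to compound 3 (0.60 log units; beyond the scatter), the same kind of shortening of the chain on the aromatic nitrogen. Taking one more carbon off that chain is therefore expected to push the number in the same direction, by a step of similar size. Such a step would carry compound 4 past the point where the assay stops reporting numbers, the point described by the limit of > 50000 nM in this assay, at which 1 of the 3 values shown sits. The expected step is a 2.1-fold higher number from compound 3 to compound 4 (0.32 log units; beyond the scatter). The estimate for compound 4 in this assay is 90000 nM, with a range from 30000 nM to 300000 nM, and there is a fair chance that only a limit, and no number, will be obtained.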

Compound 4, half-maximal inhibitory concentration: > 50000 nM
Compound 4 ended at the assay's limit; the forecaster's own chance of this, stated with the estimate: 65%; the middle value is on the limit's open side.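

Going from ethyl to methyl on the aromatic nitrogen gives an at least 1.1-fold higher number from compound 3 to compound 4 (0.06 log units; that floor lies within the scatter), so this step on its own fixes no size for the change, and a real loss cannot be told from scatter. The longer reach is clearer: methyl in place of isopropyl gives an at least 4.6-fold higher number from compound 1 to compound 4 (0.66 log units; beyond the scatter), so among the bromo compounds 1, 3 and 4, the number in this assay rises as the chain on that nitrogen shortens from isopropyl to ethyl, and the methyl compound stays on the weak side of compound 1 by a margin beyond the scatter. With compound 4, the series has also reached the end of what this read-out can express in numbers: the limit of > 50000 nM in this assay, at which 2 of the 4 values shown sit.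

On these data alone, the step from compound 2 to compound 4 cannot be read, as both values are limits, so the effect of bromo against nitro remains unknown. As far as these compounds go, it also remains open whether a longer chain such as butyl, or a cyclopropyl or hydroxyethyl group on that nitrogen, would carry the trend past compound 1, which gives 10700 nM, or would end it.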